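Ester in place of amide on the shared core

The compounds below may be only part of what the source reports. "The series", "measured", "known", "first", "only" and "open" are said of these compounds alone.

Compound 3 `Cc1cc(/C=C/C#N)cc(C)c1Oc1cc(Nc2ccc(C#N)cc2)c(N)cc1C(=O)NCCC(F)F` gives 0.233 h in an ADME assay on microsomes from liver (Homo sapiens) for metabolic stability, read by LC-MS, using NADPH, with a stated time of 45 min, tested at 1 uM (a lower number here means that the compound disappears faster, a higher number that the compound lasts longer), the lowest of the three numbers measured. Compound 1 `CCNC(=O)c1cc(N)c(Nc2ccc(C#N)cc2)cc1Oc1c(C)cc(/C=C/C#N)cc1C` gives 2.32 h in this assay, and compound 2 `Cc1cc(/C=C/C#N)cc(C)c1Oc1cc(Nc2ccc(C#N)cc2)c(N)cc1C(N)=O` gives 1.5 h; a 1.5-fold lower number from compound 1 to compound 2 (0.19 log units; within the scatter). Compound 4 `COC(=O)c1cc(N)c(Nc2ccc(C#N)cc2)cc1Oc1c(C)cc(/C=C/C#N)cc1C` differs from compound 3 by methoxy in place of (3,3-difluoropropyl)amino on a carbonyl carbon. The measured steps that bear on this are a 10-fold lower number from compound 1 to compound 3 (1.00 log units; beyond the scatter) and a 6.4-fold lower number from compound 2 to compound 3 (0.81 log units; beyond the scatter): the number fell when the 3,3-difluoropropyl chain was present, so taking it away points back toward the numbers of compound 1 and compound 2. Among the compounds with values here, no measured step compares an ester with an amide, so the size of the return is uncertain. A rise is expected, giving a 5.2-fold higher number from compound 3 to compound 4 (0.71 log units; beyond the scatter). For compound 4 the estimate in this assay is 1.2 h, with a range from 0.4 h to 3.5 h.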

Compound 4, half-life: 0.308 h
Beside the measured number, compound 4's estimate is 3.9-fold (0.59 log units) above it; measured number outside the range, below it.
By their numbers in this assay, from the lowest: compounds 3 and 4 (each within the scatter of the next); then compounds 2 and 1 (each within the scatter of the next).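

In this assay the change to methoxy gives a 1.3-fold higher number from compound 3 to compound 4 (0.12 log units; within the scatter) and so leaves methoxy and (3,3-difluoropropyl)amino on a carbonyl carbon unresolved from each other. Methoxy in place of amino gives a 4.9-fold lower number from compound 2 to compound 4 (0.69 log units; beyond the scatter) and methoxy in place of ethylamino gives a 7.5-fold lower number from compound 1 to compound 4 (0.88 log units; beyond the scatter) so a short half-life at this position does not require the 3,3-difluoropropyl chain. Nothing available accounts for these shifts.

Open: whether a carboxylic acid, a longer unfluorinated chain on the amide nitrogen or a cyclic amine on the same carbonyl carbon would group with compound 1 and compound 2 or with compound 3 and compound 4.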